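The compounds below may be only part of what the source reports. "The series", "measured", "known", "first", "only" and "open" are said of these compounds alone.

Compound 1 `CC(C)n1ncc2c(C(=O)NCc3cn(-c4ccc([N+](=O)[O-])cc4)nn3)cccc21` and compound 2 `CC(C)n1ncc2c(C(=O)NCc3cn(-c4ccc(C(F)(F)F)cc4)nn3)cccc21` share one core. In a functional assay on HepG2 cells (Homo sapiens) for inhibition, read by MTT assay, with a stated time of 72 h (on this read-out higher numbers stand for weaker inhibition and lower numbers for stronger inhibition), compound 1 returns only a limit, > 40000 nM. Compound 2 likewise returns only a limit in this assay, > 40000 nM. The step that the two limits leave unreadable from compound 1 to compound 2 therefore cannot be sized, since (the limit of > 40000 nM in this assay, at which 2 of the 2 values shown sit). Compound 3 `COc1ccc(Cn2cc(CNC(=O)c3cccc4c3cnn4C(C)C)nn2)cc1` differs from compound 2 by 4-methoxybenzyl in place of 4-(trifluoromethyl)phenyl on an aromatic nitrogen. Among the compounds with values here, no measured step bears on this change beyond the two limits, so no direction can be read for a step that the limit leaves unreadable from compound 2 to compound 3 and the expectation is a limit again or a value near it. Compound 3 is estimated at 45000 nM, between 8000 nM and 250000 nM.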

Compound 3, half-maximal inhibitory concentration: > 40000 nM
Compound 3 gave a limit, no number; the forecaster's own chance of this, stated with the estimate: 70%; the middle value does not contradict the limit.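

No new step can be read between compound 1, compound 2 and compound 3, as all three give only a limit: the limit of > 40000 nM in this assay, at which 3 of the 3 values shown sit.

The compounds shown leave open how the groups on the aromatic nitrogen compare in this assay, as none has a readable number.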